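The source may report more compounds than this note shows. Statements on the series, on what has been measured and on what is new or still open speak of the compounds shown alone.

Measured so far:
Compound 1 `COc1ccc(-c2nc3cc(F)ccc3[nH]2)c(F)c1` gives 1590 nM in an assay for inhibition of Alpha amylase (Homo sapiens), with a stated time of 10 min; a higher number here means a weaker inhibitor, a lower number a stronger inhibitor.
Compound 2 `COc1cccc(-c2nc3cc(F)ccc3[nH]2)c1Cl` gives 2620 nM in this assay.

Compound 1 and compound 2 stand within the scatter of each other, so neither can be set apart on these numbers. Compound 3 `COc1ccc(-c2nc3cc(Cl)ccc3[nH]2)c(F)c1` is not yet measured; it differs from compound 1 by chloro in place of fluoro on an aromatic carbon. For the measured compounds named here, no measured pair shows this change, so its effect is unknown, and the step from compound 1 to compound 3 is expected to be a 1.1-fold lower number from compound 1 to compound 3 (0.03 log units; within the scatter), not beyond the scatter in either direction. Compound 3 is therefore estimated at 1500 nM in this assay, with a range from 500 nM to 4500 nM.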

Compound 3, half-maximal inhibitory concentration: 2740 nM
Compound 3: middle estimate off by 1.8-fold (0.26 log units), on the low side; the measured number falls inside the stated range.
By their numbers in this assay, from the lowest: compounds 1, 2 and 3 (each within the scatter of the next).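

Chloro in place of fluoro on this aromatic carbon gives a 1.7-fold higher number from compound 1 to compound 3 (0.24 log units; within the scatter) in this assay. For the compounds shown here, this is the first matched pair at this position, and on these numbers the two halogens cannot be set apart there. Nothing on hand accounts for the size of this step.

Both groups seen at this aromatic carbon are single halogen atoms. Going by these compounds, what an amine or a carboxylic acid at the same place would do in this assay remains open.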